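A Fluorinated Side Chain Gives Way to a Four-Membered Ring

This account rests on a few compounds, and the source may have more. Where it says the series, first, only, none or still open, it means among the compounds named here.

Compound 2 `Cc1nc(S(C)(=O)=O)ccc1Oc1ncnc(OC2CCN(C(=O)O[C@H](C)C(F)(F)F)CC2)c1F` stands lowest of the two measured numbers: in a functional assay on isolated protein for inhibition of Glucose-dependent insulinotropic receptor (Rattus norvegicus), read by HTRF and cAMP accumulation (on this read-out lower numbers stand for smaller maximal responses and higher numbers for larger maximal responses), compound 2 gives 85%, while compound 1 `Cc1nc(S(C)(=O)=O)ccc1Oc1ncnc(OC2CCN(C(=O)OC(C)(C)C#N)CC2)c1F` gives 97%. For the measured compounds named here, the one known step, a number 12 percentage points lower from compound 1 to compound 2 (beyond the scatter), swapped one group for another on an oxygen next to a carbonyl group. Compound 3 `Cc1nc(S(C)(=O)=O)ccc1Oc1ncnc(OC2CCN(C(=O)C3(F)CCC3)CC2)c1F` alters a different kind of piece: a group of 5 heavy atoms (4 carbon, 1 fluorine; one four-membered non-aromatic ring of carbon only) in place of a group of 7 heavy atoms (3 carbon, 1 oxygen, 3 fluorine; no ring), on a carbonyl carbon. Going by the values given here, no measured step covers such a change, so only the modest size of the step from compound 1 to compound 2 offers guidance. Compound 3 is therefore expected to give about 85%, between 70% and 98%. The step of no change at the digits printed from compound 2 to compound 3 (within the scatter) this implies is estimated to stay within the usual scatter.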

Compound 3, largest response reached (reported as efficacy), in percent of the reference or control that the assay uses: 91%
Estimate against measurement, compound 3: 6 percentage points below; low and high end bracket the measured number.
By their numbers in this assay, from the lowest: compounds 2, 3 and 1 (each within the scatter of the next, the first and the last beyond it).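

On this carbonyl carbon, a group with one four-membered non-aromatic ring of carbon only can take the place of either open-chain group while the response in this assay stays within the scatter: the result is a number 6 percentage points higher from compound 2 to compound 3 (within the scatter), and a number 6 percentage points lower from compound 1 to compound 3 (within the scatter). Compound 3 therefore lies within the scatter of both compound 1 and compound 2, although those two lie beyond it from each other. Nothing available here explains this result.

Still open, from the compounds shown here alone, is whether the fluorine on the ring matters, and how a cyclohexyl group or an amine would read on this carbonyl carbon.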